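Bromo for Ethyl on the Aryl Ring of Compound 2

The source may report more compounds than this note shows. Statements on the series, on what has been measured and on what is new or still open speak of the compounds shown alone.

Of the compounds shown here, three built on one shared core have been measured in a functional assay on K562 cells (Homo sapiens) for inhibition; a lower number here means a stronger inhibitor, a higher number a weaker inhibitor. Compound 1 `O=C1C=CC(OCC(F)(F)F)N1c1cc(Cl)cc(Cl)c1` gives 1640 nM, compound 2 `CCc1ccc(N2C(=O)C=CC2OCC(F)(F)F)cc1` gives 4470 nM, and compound 3 `O=C1C=CC(OC(C(F)(F)F)C(F)(F)F)N1c1ccc(Cl)cc1` gives 4480 nM. Compound 2 thus stands second highest of the three: its number and that of compound 3 lie within the scatter of each other, while compound 1 sits beyond the scatter with the lower number. Compound 4 `O=C1C=CC(OCC(F)(F)F)N1c1ccc(Br)cc1` has not yet been measured. It differs from compound 2 in one place: bromo in place of ethyl on an aromatic carbon, para to a large group. For the measured compounds named here, no measured pair shows this exact change, so its size is uncertain. A modest move toward a lower number is expected, a 1.5-fold lower number from compound 2 to compound 4 (0.17 log units; within the scatter), though it may well remain within the scatter. Compound 4 is accordingly estimated at 3000 nM, with a range from 1200 nM to 7500 nM.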

Compound 4, half-maximal inhibitory concentration: 3270 nM
For compound 4 the middle estimate is 1.1-fold (0.04 log units) below the measured one; the measured number falls inside the stated range.
By their numbers in this assay, from the lowest: compounds 1, 4, 2 and 3 (each within the scatter of the next, the first and the last beyond it).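

In this assay this aromatic carbon, para to a large group, now has its first single-place change: bromo in place of ethyl gives a 1.4-fold lower number from compound 2 to compound 4 (0.14 log units; within the scatter) and so does not move the number beyond the scatter. Ethyl and bromo therefore read alike at this position, although one bromine replaces two carbons. Nothing available accounts for this likeness. From the compounds shown here alone, whether an amine or a carboxylic acid on this same carbon would shift the number beyond the scatter remains open. So does whether this step would hold on compounds carrying a different ether chain on the shared core.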